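Dropping One Fluorine from a Benzyl Group

The source may report more compounds than this note shows. Statements on the series, on what has been measured and on what is new or still open speak of the compounds shown alone.

Of the compounds shown here, two have been tested in a functional assay on BAEC cells (Bos taurus) for antiproliferative activity, read by cell counting, with a stated time of 4 days; on this read-out lower numbers stand for stronger inhibition and higher numbers for weaker inhibition. Compound 1, `CCOC(=O)C(=O)N(Cc1ccccc1)c1ccc2c(c1)OC(C)(CO)CN2C`, gives no number at all. For compound 1 the read-out stops at a limit of > 100000 nM, a position summed up by the limit of > 100000 nM in this assay, at which 1 of the 2 values shown sits. Compound 2, `CCOC(=O)CN(Cc1cc(F)cc(F)c1)c1ccc2c(c1)N(C)CC(C)(COc1ccc(C(=N)N)cc1)O2`, carries a 3,5-difluorobenzyl group on a nitrogen attached to the shared core, together with a large group elsewhere in the molecule. In this assay, for the measured compounds named here, compound 2 gives 4000 nM, the only number among the two values shown. Compound 3, `CCOC(=O)CN(Cc1cccc(F)c1)c1ccc2c(c1)N(C)CC(C)(COc1ccc(C(=N)N)cc1)O2`, differs from compound 2 in a single place: hydrogen in place of fluoro on an aromatic carbon Written one bond further out, the 3,5-difluorobenzyl becomes a 3-fluorobenzyl. Going by the values given here, no pair of measured compounds separated by one change is available here, so the size of such a step cannot be read from a precedent. Removing one fluorine is a small change by atom count; the step is expected to stay within the usual scatter, or to weaken inhibition only slightly. Compound 3 is therefore estimated at 5000 nM, with a range from 2000 nM to 15000 nM. The step expected here is a 1.3-fold higher number from compound 2 to compound 3 (0.10 log units; within the scatter).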

Compound 3, half-maximal inhibitory concentration: 3900 nM
Estimate against measurement, compound 3: 1.3-fold (0.11 log units) above, and the stated range covers the measured number.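

For the compounds shown here, this is the first step between two measured compounds that differ in one place, and it gives a direct reading of the 3,5-difluorobenzyl group in this assay: replacing one fluoro group with hydrogen gives a 1.0-fold lower number from compound 2 to compound 3 (0.01 log units; within the scatter), so the 3-fluorobenzyl group keeps inhibition at the same level. In this pair, with the rest of the molecule unchanged, the second fluoro group on the six-membered aromatic ring makes no difference that can be told apart from ordinary repeat variation. Nothing available here offers an explanation for this result.

As far as these compounds go, both compounds keep a fluoro group on that ring, so it remains open how a chloro or methoxy group at the same place would behave, or what would happen if the remaining fluoro group were also replaced by hydrogen with the rest of the molecule unchanged. Compound 1 stands at > 100000 nM, which is a limit of the assay, and it differs from compound 3 in several places, so it says nothing about this fluoro group.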